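A sulfonyl swap in a series sitting at a limit

This account rests on a few compounds, and the source may have more. Where it says the series, first, only, none or still open, it means among the compounds named here.

Compound 1 `NCCCCN(C[C@H]1CN(C(=O)OCc2ccccc2)CCN1)[C@H]1CCCc2cccnc21`, compound 2 `NCCCCN(C[C@H]1CN(S(=O)(=O)c2ccc3ccccc3c2)CCN1)[C@H]1CCCc2cccnc21` and compound 3 `NCCCCN(C[C@H]1CN(S(=O)(=O)c2cc3ccccc3s2)CCN1)[C@H]1CCCc2cccnc21` share one core. In an ADME assay on MAGI cells (Homo sapiens) for cytotoxicity (a lower number here means that less compound is tolerated, a higher number that more compound is tolerated), compound 1 gives > 10 uM, which is a limit. Compound 2 likewise gives only a limit, > 10 uM. Compound 3 also stands at a limit, > 10 uM. Every reading therefore lies at the limit of > 10 uM in this assay, at which 3 of the 3 values shown sit.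

Compound 4 `NCCCCN(C[C@H]1CN(S(=O)(=O)c2ccc(Cl)cc2)CCN1)[C@H]1CCCc2cccnc21` carries 4-chlorophenyl in place of 1-benzothiophen-2-yl on a sulfonyl sulfur. Among the measured compounds shown here, only one measured step touches that sulfur, a step that the two limits leave unreadable from compound 2 to compound 3, so it offers no size to carry over. No step beyond the scatter, in either direction, is expected in this assay: the expected step is a step that the limit leaves unreadable from compound 3 to compound 4. For compound 4 the estimated value is 14 uM, with an expected range of 8 uM to 40 uM.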

Compound 4, half-maximal toxic concentration: > 10 uM
Compound 4: a limit, no number; the forecaster's own chance of this, stated with the estimate: 85%; the middle value is on the limit's open side.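

In this assay compound 4 gives > 10 uM, which is a limit, so its steps from compound 1, compound 2 and compound 3 cannot be read. The compounds shown leave open whether their tolerated concentrations differ at all, because every reading stands at: the limit of > 10 uM in this assay, at which 4 of the 4 values shown sit.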